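The source may hold more compounds than are shown below. What is called first, only, known or untested is meant among the compounds shown, and "the series" means these compounds.

Compound 1 `CCOc1cc(CN(C)C(=O)c2c(OCCCC3CCN(C(=O)OC(C)(C)C)CC3)c3ccccc3n(C)c2=O)cc(OCC)c1`: < 0.08 ug/mL
Compound 2 `CN(Cc1cc(C(F)(F)F)cc(C(F)(F)F)c1)C(=O)c1c(OCCCC2CCN(C(=O)OC3(C)CC3)CC2)c2cccnc2n(C)c1=O`: < 0.3 ug/mL

Both of these values are limits of a physicochemical assay for solubility, read by LC-MS, at pH 6.8 (a higher number here means a more soluble compound, a lower number a less soluble compound), rather than measured numbers. Compound 1 stands at the limit of < 0.08 ug/mL in this assay, at which 1 of the 2 values shown sits. Compound 2 stands at the limit of < 0.3 ug/mL in this assay, at which 1 of the 2 values shown sits. Compound 3 `COc1cc(CN(C)C(=O)c2c(OCCCC3CCN(C(=O)OC(C)(C)C)CC3)c3ccccc3n(C)c2=O)cc(OC)c1` has not yet been measured; it differs from compound 1 in one place, (3,5-dimethoxyphenyl in place of 3,5-diethoxyphenyl on a saturated chain carbon bound to an amide-type nitrogen). Within the data shown here, no pair of measured compounds shows what such a change does here. For compound 3 the step of an at least 1.5-fold higher number from compound 1 to compound 3 (0.17 log units; that floor lies within the scatter) is expected to be small, at the edge of the scatter, towards higher solubility. Compound 3 is therefore estimated to give about 0.12 ug/mL in this assay, within 0.03 ug/mL to 0.5 ug/mL.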

Compound 3, solubility: 1.8 ug/mL
Beside the measured number, compound 3's estimate is 15-fold (1.18 log units) below it; the measured number lies above the stated range.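

In this assay, the place on a saturated chain carbon bound to an amide-type nitrogen proves highly sensitive to a small edit: 3,5-dimethoxyphenyl in place of 3,5-diethoxyphenyl gives an at least 22-fold higher number from compound 1 to compound 3 (1.35 log units; beyond the scatter) on an otherwise unchanged structure. The ring and its two ether oxygens stay, so trimming the ether chains alone is enough for a large step. The reading for compound 1 is a limit, not a number: the limit of < 0.08 ug/mL in this assay, at which 1 of the 3 values shown sits. From the compounds shown here alone, the true size of this step therefore stays open. So does what an amine or a carboxylic acid would do at this place.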